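Iodo for Methyl on the Core of Compound 2

The compounds below may be only part of what the source reports. "The series", "measured", "known", "first", "only" and "open" are said of these compounds alone.

For the measured compounds named here, compound 2 `Cc1cn([C@H]2C[C@H](O)[C@@H](CO)O2)c(=O)n(/C=C/C=O)c1=O` holds the only number in a functional assay on HeLa cells (Homo sapiens) for inhibition (a higher number here means a weaker inhibitor, a lower number a stronger inhibitor), where compound 2 gives 500 nM. Compound 1 `Cc1cn(/C=C/C=N/O)c(=O)[nH]c1=O` reaches only the limit of the assay, > 100000 nM, in this assay. Compound 3 `Cc1cn([C@@H]2O[C@H](CO)[C@@H](O)[C@H]2O)c(=O)n(/C=C/C=O)c1=O` likewise stops at the limit, > 100000 nM, in this assay. Going by the values given here, the one step between measured compounds, an at least 200-fold higher number from compound 2 to compound 3 (2.30 log units; beyond the scatter), is large, and the limit of > 100000 nM in this assay, at which 2 of the 3 values shown sit, marks where both limits sit.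

Compound 4 `O=C/C=C/n1c(=O)c(I)cn([C@H]2C[C@H](O)[C@@H](CO)O2)c1=O` differs from compound 2 in that (iodo in place of methyl on an aromatic carbon). Among the compounds with values here, no measured step touches this aromatic carbon: the step from compound 2 to compound 3 concerns a saturated ring carbon, and the values of compound 1 and compound 2 show only that one sits at the limit and the other at a number. Nothing in the measured data therefore speaks to the size of the step from compound 2 to compound 4, and a step within the scatter is expected in this assay, in no particular direction. Compound 4 is accordingly estimated at 600 nM in this assay, with a range from 150 nM to 3000 nM. The expected step is a 1.2-fold higher number from compound 2 to compound 4 (0.08 log units; within the scatter).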

Compound 4, half-maximal inhibitory concentration: 300 nM
Compound 4: middle estimate off by 2.0-fold (0.30 log units), on the high side, and the stated range covers the measured number.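

In this assay, for the compounds shown here, the exchange of methyl for iodo on the aromatic carbon gives a 1.7-fold lower number from compound 2 to compound 4 (0.22 log units; within the scatter), so the first measured change at this position leaves the two values within the scatter of each other. Going by these compounds alone, this position therefore differs from the saturated ring carbon, where the only other step that can be read is an at least 200-fold higher number from compound 2 to compound 3 (2.30 log units; beyond the scatter), a step beyond the scatter, and a single-atom exchange of methyl for iodo here does not carry the inhibition away to the limit of the assay. No measurement shown here gives a reason for this outcome.

Methyl and iodo are the only two groups seen on this aromatic carbon, so it remains open whether a hydrogen, an amine, a carboxylic acid or a longer chain would also keep the value within the scatter of the one for compound 2. As far as these compounds go, it also remains open whether iodo in place of methyl would give a readable number on the core of compound 3, which carries the extra hydroxy on its saturated ring.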